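This account rests on a few compounds, and the source may have more. Where it says the series, first, only, none or still open, it means among the compounds named here.

Working notes on the series. In a functional assay on L5178Y cells (Mus musculus) for inhibition, read by MTT assay, with a stated time of 24 h (on this read-out higher numbers stand for weaker inhibition and lower numbers for stronger inhibition), compound 1 `O=C(N/N=C1\C[C@@H](c2ccc(O)cc2)Oc2cc(O)cc(O)c21)c1ccco1` gives >= 11300 nM, which is a limit of the assay and not a number. In this assay, compound 2 `COc1cc(O)c2c(c1)O[C@H](c1ccc(O)cc1)C/C2=N\NC(=O)c1ccc(C(F)(F)F)cc1` gives >= 11300 nM, again a limit and not a number. Compound 2 therefore has no exact position on the scale, and the same is true of compound 1. The record so far is the limit of >= 11300 nM in this assay, at which 2 of the 2 values shown sit. For the measured compounds named here, no step between measured compounds is available for calibration.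

The next compound is compound 3 `COc1cc(O)c2c(c1)O[C@H](c1ccc(O)cc1)C/C2=N\NC(=O)OCc1ccccc1`, which carries benzyloxy in place of 4-(trifluoromethyl)phenyl on a carbonyl carbon. The same aromatic ring count appears on both sides of this change, and the entering group adds one hydrogen-bond acceptor.

In this assay, no change beyond the usual scatter is expected, and no direction is favoured. The expectation rests on compound 2 with its limit of >= 11300 nM. The expected move is a step that the limit leaves unreadable from compound 2 to compound 3. For compound 3 the estimate is 12000 nM, with an expected range of 5000 nM to 30000 nM, and a further limit rather than a number is the likeliest report.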

Compound 3, half-maximal inhibitory concentration: >= 11300 nM
Compound 3: only a limit was reported (the forecaster's own chance of this, stated with the estimate: 70%); the middle value does not contradict the limit.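

Compound 2 and compound 3 are both reported only as limits in this assay, so no step can be read between them. The compounds shown leave open where any of them lies on the scale and whether benzyloxy in place of 4-(trifluoromethyl)phenyl changes inhibition at all, with the record standing at: the limit of >= 11300 nM in this assay, at which 3 of the 3 values shown sit.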